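Hydroxy to a pyridinylcarbonyl ester on a shared core

The source may hold more compounds than are shown below. What is called first, only, known or untested is meant among the compounds shown, and "the series" means these compounds.

Compound 1 `CC(=O)Oc1ccccc1C(=O)O[C@H]1CO[C@H]2[C@@H]1OC[C@H]2O` carries a free hydroxy on its core. In an ADME assay on a cell-free system (plasma, Homo sapiens) for metabolic stability, with Plasma (Rattus norvegicus) as the target, read by HPLC, at pH 7.4 (a lower number here means that the compound disappears faster, a higher number that the compound lasts longer), compound 1 gives 0.055 h, the lowest of the two plain numbers shown; the nearest is compound 2, within the scatter. Compound 2 `CC(=O)Oc1ccccc1C(=O)O[C@H]1CO[C@H]2[C@@H]1OC[C@H]2OC(C)=O` is the acetyl ester of that hydroxy, and in this assay compound 2 gives 0.0608 h; the step is a 1.1-fold higher number from compound 1 to compound 2 (0.04 log units; within the scatter). Compound 3 `CC(=O)Oc1ccccc1C(=O)O[C@H]1CO[C@H]2[C@@H]1OC[C@H]2OC(=O)c1ccc(-c2ccccc2)cc1` carries a larger ester group. In this assay compound 3 reaches only a limit, > 0.333 h, and no number. That is the limit of > 0.333 h in this assay, at which 1 of the 3 values shown sits. The step from the acetyl ester to this larger ester is an at least 5.4-fold higher number from compound 2 to compound 3 (0.73 log units; beyond the scatter).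

Compound 4 `CC(=O)Oc1ccccc1C(=O)O[C@H]1CO[C@H]2[C@@H]1OC[C@H]2OC(=O)c1cccnc1` has not yet been measured. It differs from compound 1 by (pyridin-3-yl)carbonyl in place of hydrogen on an oxygen on a saturated carbon. The two measured steps together show that replacing the hydroxy with an acetyl ester changed little, while a larger aromatic ester lifted the number beyond the scatter. Compound 4 also carries an aromatic ester on the same oxygen, so a higher number is expected in this assay, though the pyridinyl ring is smaller than the 4-phenylphenyl of compound 3. Compound 4 is therefore expected to give 0.2 h in this assay, between 0.08 h and 0.5 h. That estimate means an expected step of a 3.6-fold higher number from compound 1 to compound 4 (0.56 log units; beyond the scatter).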

Compound 4, half-life: 0.0232 h
The estimate for compound 4 lay 8.6-fold (0.94 log units) above the measured number; the whole stated range lies above it.
By their numbers in this assay, from the lowest: compound 4; then compounds 1 and 2 (each within the scatter of the next). At a limit, above all of these: compound 3.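

The aromatic ester on this oxygen does not lift the number in this assay on its own: putting (pyridin-3-yl)carbonyl in place of hydrogen gives a 2.4-fold lower number from compound 1 to compound 4 (0.37 log units; beyond the scatter) and not a rise, while pyridin-3-yl in place of methyl on the carbonyl carbon gives a 2.6-fold lower number from compound 2 to compound 4 (0.42 log units; beyond the scatter) even though the acetyl ester itself changed little. The group on the carbonyl carbon can therefore move the number in either direction, and compound 3 goes against any reading that aromatic esters as a set lower it, with pyridin-3-yl in place of 4-phenylphenyl giving an at least 14-fold lower number from compound 3 to compound 4 (1.15 log units; beyond the scatter) as the largest step in the series. From the compounds shown here alone, compound 3 stands at a limit and not at a number, so the full size of that last step stays unknown: the limit of > 0.333 h in this assay, at which 1 of the 4 values shown sits.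

Going by these compounds alone, with only two aromatic groups on this carbonyl carbon, the compounds cannot separate the effect of the ring nitrogen from that of the second phenyl ring, a comparison that a plain phenyl in the same place would address. They also leave open how an amine or a carboxylic acid on the ring would fare, and the half-life alone does not tell which of the ester bonds is cut first.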